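The compounds below may be only part of what the source reports. "The series", "measured", "known", "first", "only" and "open" are said of these compounds alone.

In a functional assay (aorta, strain Wistar) for inhibition, with Rattus norvegicus as the target (on this read-out lower numbers stand for stronger inhibition and higher numbers for weaker inhibition), compound 2 `CCCCc1nc(Cl)c(COC(=O)c2ccc(C(C)O[N+](=O)[O-])cc2)n1Cc1ccc(-c2ccccc2-c2nn[nH]n2)cc1` is the higher of the two measured compounds at 7760 nM, while compound 1 `CCCCc1nc(Cl)c(COC(=O)c2cccc(CO[N+](=O)[O-])c2)n1Cc1ccc(-c2ccccc2-c2nn[nH]n2)cc1` gives 275 nM. Compound 3 `CCCCc1nc(Cl)c(COC(=O)c2cccc(CO[N+](=O)[O-])n2)n1Cc1ccc(-c2ccccc2-c2nn[nH]n2)cc1` has 6-((nitrooxy)methyl)pyridin-2-yl in place of 4-(1-(nitrooxy)ethyl)phenyl on a carbonyl carbon. For the measured compounds named here, the one measured step bearing on this is large: a 28-fold higher number from compound 1 to compound 2 (1.45 log units; beyond the scatter). Compound 3 carries a (nitrooxy)methyl group, as does compound 1 at 275 nM. Going by the values given here, no measured step covers the ring hetero atom, so the range stays wide. A large step to a lower number is expected: a 19-fold lower number from compound 2 to compound 3 (1.29 log units; beyond the scatter). The estimate for compound 3 is 400 nM, with a range of 120 nM to 1500 nM.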

Compound 3, half-maximal inhibitory concentration: 12300 nM
The estimate for compound 3 lay 31-fold (1.49 log units) below the measured number; measured number above the stated range.
By their numbers in this assay, from the lowest: compound 1; then compounds 2 and 3 (each within the scatter of the next).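

In this assay, a (nitrooxy)methyl group alone does not keep the low number of compound 1: 6-((nitrooxy)methyl)pyridin-2-yl in place of 3-((nitrooxy)methyl)phenyl on the carbonyl carbon gives a 45-fold higher number from compound 1 to compound 3 (1.65 log units; beyond the scatter) at this position. Against 4-(1-(nitrooxy)ethyl)phenyl, the same pyridinyl group gives a 1.6-fold higher number from compound 2 to compound 3 (0.20 log units; within the scatter), so these two different groups cannot be separated by this read-out. Nothing available explains the loss seen with either group.

Still open, on these data alone, is whether 4-((nitrooxy)methyl)phenyl would stay near compound 1 or near compound 2, which would separate ring position from the branched ethyl chain. Also open, as far as these compounds go, is whether a longer nitrooxyalkyl chain on the pyridine ring would recover the number of compound 1.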